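The compounds below may be only part of what the source reports. "The series", "measured", "known", "first", "only" and "open" are said of these compounds alone.

Of the compounds shown here, two have so far been measured in an ADME assay on microsomes from liver (Rattus norvegicus) for metabolic stability, with a stated time of 10 min; a lower number here means that less of the compound is left, a higher number that more of the compound is left. Compound 1, `CCCc1onc(-c2ccc(Cl)cc2)c1COc1ccc(CCC(=O)O)c(C)c1C`, gives 38.4% in this assay. Going by the values given here, compound 2, `O=C(O)CCc1cc(F)c(OCc2c(-c3ccc(F)cc3)noc2C(F)(F)F)c(F)c1`, gives 66.2% in this assay, which is the higher of the two numbers; the only other number, that of compound 1, lies well below it, farther than the usual scatter of repeated measurements.

Compound 3, `Cc1ccc(-c2noc(C(F)(F)F)c2COc2c(F)cc(CCC(=O)O)cc2F)cc1`, has not yet been measured in this assay. It differs from compound 2 in a single spot: methyl in place of fluoro on an aromatic carbon. Read one bond further out, a 4-fluorophenyl becomes a 4-methylphenyl, while the trifluoromethyl, the two remaining fluoro groups and the acid chain are kept as they are.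

No measured pair among these compounds shows this swap, so there is no direct step to lean on, and the expectation rests on compound 2 alone. A moderate downward step is expected, a number 14.2 percentage points lower from compound 2 to compound 3 (beyond the scatter), though an outcome within the scatter cannot be ruled out. Compound 3 is therefore estimated to give 52% in this assay, within a range from 32% to 72%.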

Compound 3, percent of the compound remaining: 37.9%
The estimate for compound 3 lay 14.1 percentage points above the measured number, and the stated range covers the measured number.
By their numbers in this assay, from the lowest: compounds 3 and 1 (each within the scatter of the next); then compound 2.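

In this assay, putting methyl in place of fluoro on this aromatic carbon, which turns a 4-fluorophenyl into a 4-methylphenyl, gives a number 28.3 percentage points lower from compound 2 to compound 3 (beyond the scatter). Going by these compounds alone, this is the first direct reading at this position, and it shows that the position is not a silent one: exchanging one heavy atom for another, with the trifluoromethyl, the two remaining fluoro groups and the acid chain all kept, is enough to move the number by more than repeated measurements would scatter. Nothing measured here says why this single swap has an effect of this size, so the step stands as an observation without an explanation.

The compounds shown leave open how other groups on this aromatic carbon would read in this assay, for instance a nitrile, a methoxy group or a longer chain such as ethyl. From the compounds shown here alone, it also remains open whether the same swap from fluoro to methyl gives a step of similar size on a different core, as this one pair is the only one that carries it so far.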